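The source may report more compounds than this note shows. Statements on the series, on what has been measured and on what is new or still open speak of the compounds shown alone.

Compound 1 `CNc1nc(Cl)nc2c1ncn2[C@@H]1O[C@H](C(=O)NCc2cccc(F)c2)[C@@H](O)[C@H]1O` gives 17.4 nM in an assay on CHO cells for displacement of a labelled ligand from adenosine receptor A3 (Homo sapiens); a lower number here means a stronger inhibitor, a higher number a weaker inhibitor.
Compound 2 `CCNC(=O)[C@H]1O[C@@H](n2cnc3c(NC4CC4)nc(Cl)nc32)[C@H](O)[C@@H]1O` gives 0.676 nM in this assay.
Compound 3 `CCNC(=O)[C@H]1O[C@@H](n2cnc3c(NCc4cccc(I)c4)nc(Cl)nc32)[C@H](O)[C@@H]1O` gives 0.891 nM in this assay.

Among these three numbers compound 3 stands second highest. Its nearest neighbour is compound 2; the step of a 1.3-fold higher number from compound 2 to compound 3 (0.12 log units; within the scatter) shows that the two cannot be told apart. Compound 1, with 17.4 nM, lies well beyond the scatter of compound 3.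

Compound 4 `O=C(NCC1CC1)[C@H]1O[C@@H](n2cnc3c(NCc4cccc(I)c4)nc(Cl)nc32)[C@H](O)[C@@H]1O` is made from compound 3 by the change (cyclopropyl in place of methyl on a saturated chain carbon bound to an amide-type nitrogen). No measured step touches this part of the molecule: the only step shown, from compound 2 to compound 3, concerns the group on the nitrogen on the aromatic ring, and compound 1 differs from compound 3 in two places at once, so its value gives no clean guide either. The change adds a small ring but no hydrogen-bond donor or acceptor, and the shared core is kept. The estimated step of a 1.7-fold higher number from compound 3 to compound 4 (0.23 log units; within the scatter) is therefore expected to be small, if anything a slightly higher number. Compound 4 is expected to give about 1.5 nM in this assay, most likely between 0.4 nM and 6 nM.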

Compound 4, inhibition constant: 3.63 nM
Beside the measured number, compound 4's estimate is 2.4-fold (0.38 log units) below it, within the range that was stated.
By their numbers in this assay, from the lowest: compounds 2 and 3 (each within the scatter of the next); then compound 4; then compound 1.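

Among the compounds shown here, replacing ethylcarbamoyl with (cyclopropylmethyl)carbamoyl gives the first change in this assay at this position that can be told from the scatter: a 4.1-fold higher number from compound 3 to compound 4 (0.61 log units; beyond the scatter) is a modest weakening. The earlier step of a 1.3-fold higher number from compound 2 to compound 3 (0.12 log units; within the scatter) could not be told apart from the scatter, although it swapped cyclopropyl for the much larger 3-iodobenzyl on the nitrogen on the aromatic ring, so the two sites differ in these compounds, while this one step shows that the number can respond to the group on the amide-type nitrogen. Nothing available explains the loss.

As far as these compounds go, whether the ring itself or only the larger size of the group matters stays open, and a straight propyl or butyl chain at this position would help separate the two. From the compounds shown here alone, it is also open whether the same change would cost as much with cyclopropyl in place of 3-iodobenzyl on the nitrogen on the aromatic ring.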